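The compounds below may be only part of what the source reports. "The series", "measured", "known", "first", "only" and "open" are said of these compounds alone.

Measured so far:
compound 1 `COc1cc2c(c(O)c1OC)C(=O)[C@]1(OC)C=C[C@H]2N(C(=O)OCC(C)C)N1C(=O)OCC(C)C`: > 300 ug/mL
compound 2 `CCOC(=O)N1[C@@H]2C=C[C@@](OC)(C(=O)c3c2cc(OC)c(OC)c3OCc2ccc(OC)cc2)N1C(=O)OCC`: 63.1 ug/mL

In an ADME assay on KB cells (Homo sapiens) for cytotoxicity (a lower number here means that less compound is needed, a higher number that more compound is needed for the effect), compound 1 gives > 300 ug/mL, which is a limit of the assay rather than a number, sitting at the limit of > 300 ug/mL in this assay, at which 1 of the 2 values shown sits. Compound 2 gives 63.1 ug/mL in this assay. Compound 3 `COc1cc2c(c(OC)c1OC)C(=O)[C@]1(OC)C=C[C@H]2N(C(=O)OCC(C)C)N1C(=O)OCC(C)C` has not yet been measured; it differs from compound 1 by methyl in place of hydrogen on an oxygen on an aromatic ring. Going by the values given here, no step between measured compounds is known, so there is no measured change to lean on. The expected step is a number no higher from compound 1 to compound 3 (the limit leaves the size open), none beyond the scatter. Compound 3 is expected to give about 300 ug/mL in this assay, in the range 100 ug/mL to 1000 ug/mL, most likely again reported only as a limit.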

Compound 3, concentration for half-maximal effect: > 300 ug/mL
Compound 3: a limit, no number; the forecaster's own chance of this, stated with the estimate: 60%; the middle value lies on the limit itself.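

No step can be read from compound 1 to compound 3 in this assay because both compounds stand only as limits: the limit of > 300 ug/mL in this assay, at which 2 of the 3 values shown sit.

The compounds shown leave open whether going from hydroxy to methoxy on this core changes the value in this assay at all.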